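Furan-2-yl in place of 2-methoxyphenyl: expected cytotoxicity

The source may hold more compounds than are shown below. What is called first, only, known or untested is meant among the compounds shown, and "the series" means these compounds.

Of the compounds shown here, two of the shared core have numbers so far. Compound 1 `COc1ccccc1-c1nnc(SCCn2c([N+](=O)[O-])cnc2C)o1` gives 10800 nM in a functional assay on MCF7 cells (Homo sapiens) for cytotoxicity, read by MTT assay, with a stated time of 48 h; on this read-out higher numbers stand for weaker inhibition and lower numbers for stronger inhibition. Compound 2 `COc1cc(-c2nnc(SCCn3c([N+](=O)[O-])cnc3C)o2)cc(OC)c1OC` gives 30600 nM in this assay, a higher number than compound 1, beyond the scatter. Compound 1 thus stands at the lower of the two numbers, with compound 2 the nearest and only other point.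

Compound 3 `Cc1ncc([N+](=O)[O-])n1CCSc1nnc(-c2ccco2)o1` has not been measured. It differs from compound 1 in one place: furan-2-yl in place of 2-methoxyphenyl on an aromatic carbon. Going by the values given here, no step between measured compounds that changes only this position is available, so nothing itself sets the size of the change.

The expected step is a 1.1-fold higher number from compound 1 to compound 3 (0.05 log units; within the scatter), none beyond the scatter. Among the compounds with values here, compound 3 is expected to give about 12000 nM in this assay, with a range from 4000 nM to 36000 nM, because the only anchor is compound 1 at 10800 nM.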

Compound 3, half-maximal inhibitory concentration: 29500 nM
The estimate for compound 3 lay 2.5-fold (0.39 log units) below the measured number, and the stated range covers the measured number.
By their numbers in this assay, from the lowest: compound 1; then compounds 3 and 2 (each within the scatter of the next).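

Furan-2-yl in place of 2-methoxyphenyl on this aromatic carbon is not a neutral swap: in this assay it gives a 2.7-fold higher number from compound 1 to compound 3 (0.44 log units; beyond the scatter), the first single-change step measured at this position. Compound 1 keeps the lowest number of the three, while compound 3 and compound 2 lie within the scatter of each other, so two quite different groups here give similar numbers. Nothing measured on these compounds bears on why the number rises with this change.

Open, as far as these compounds go, is whether unsubstituted phenyl at this position would stay with compound 1 or with compound 3 and compound 2, which would show whether the methoxy group matters or the ring itself. A pyridin-3-yl ring or a thiophen-2-yl ring here would also test how far this position tolerates other aromatic rings.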